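Swapping Acetyl for Pyrrole: Expected Cytotoxicity of Compound 4

The compounds below may be only part of what the source reports. "The series", "measured", "known", "first", "only" and "open" are said of these compounds alone.

Compound 1 `CC(=O)c1ccc(NCc2cncn2Cc2ccc(-c3ccccc3)cc2)cc1-c1ccccc1` was tested in a toxicity assay on NIH3T3 cells (Mus musculus) for cytotoxicity, read by resazurin assay; a lower number here means that less compound is needed, a higher number that more compound is needed for the effect. For compound 1 the result is only a limit, > 10000 nM, not an exact number. Compound 2 `CCc1ccc(Cn2cncc2CNc2ccc(-c3nc4ccccc4s3)c(-c3ccccc3)c2)cc1` likewise gives only a limit in this assay, > 1000 nM. Compound 3 `COC(=O)c1ccc(NCc2cncn2Cc2ccccc2C#N)cc1-c1ccccc1` gives a measured value of 25000 nM in this assay. Compound 1 thus sits at the limit of > 10000 nM in this assay, at which 1 of the 3 values shown sits, while compound 2 sits at the limit of > 1000 nM in this assay, at which 1 of the 3 values shown sits; none of the three compounds shows marked cytotoxicity. Compound 4 `c1ccc(-c2ccc(Cn3cncc3CNc3ccc(-c4ccc[nH]4)c(-c4ccccc4)c3)cc2)cc1` differs from compound 1 by 1H-pyrrol-2-yl in place of acetyl on an aromatic carbon. Going by the values given here, no measured pair isolates this change, so its effect is unknown; the expected step is a step that the limit leaves unreadable from compound 1 to compound 4, hardly beyond the usual scatter. For compound 4 the estimate in this assay is 20000 nM, between 5000 nM and 60000 nM.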

Compound 4, half-maximal effective concentration: > 10000 nM
Compound 4 ended at the assay's limit (the forecaster's own chance of this, stated with the estimate: 60%); the middle value is on the limit's open side.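

Compound 4 gives > 10000 nM, which is a limit. Going by these compounds alone, compound 1 also gives only a limit, so no step between the two can be read. From the compounds shown here alone, whether 1H-pyrrol-2-yl in place of acetyl changes cytotoxicity at all remains open.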